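The source may hold more compounds than are shown below. What is called first, only, known or untested is meant among the compounds shown, and "the series" means these compounds.

Measured so far:

compound 1 `CN1CCN(c2ncc3c(n2)CCN(C(=O)c2cc(Cc4n[nH]c(=O)c5ccccc45)ccc2F)C3)CC1` — 53400 nM
compound 2 `O=C(c1cc(Cc2n[nH]c(=O)c3ccccc23)ccc1F)N1CCc2nc(N3CCCCC3)ncc2C1` — > 200000 nM
compound 3 `CN(C)CCN(C)c1ncc2c(n1)CCN(C(=O)c1cc(Cc3n[nH]c(=O)c4ccccc34)ccc1F)C2` — > 200000 nM

In a functional assay on HCC1937 cells (Homo sapiens) for inhibition, read by MTT assay, with a stated time of 48 h (a higher number here means a weaker inhibitor, a lower number a stronger inhibitor), compound 1 gives 53400 nM. Compound 2 gives only a limit of the assay, > 200000 nM. Compound 3 likewise reaches only a limit, > 200000 nM, so for compound 3 no number is known, only that it sits at the limit of > 200000 nM in this assay, at which 2 of the 3 values shown sit. The two changes away from compound 1 both run the same way: an at least 3.7-fold higher number from compound 1 to compound 2 (0.57 log units; beyond the scatter) and an at least 3.7-fold higher number from compound 1 to compound 3 (0.57 log units; beyond the scatter). Between the two limits, a step that the two limits leave unreadable from compound 2 to compound 3, so nothing can be read there.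

Compound 4 `CCCCN(CCCC)c1ncc2c(n1)CCN(C(=O)c1cc(Cc3n[nH]c(=O)c4ccccc34)ccc1F)C2` differs from compound 3 in one place: dibutylamino in place of (2-(dimethylamino)ethyl)(methyl)amino on an aromatic carbon. Going by the values given here, no measured step swaps one acyclic amine for another, so none bears on this change directly; the steps from compound 1 only show that both departures from the 4-methylpiperazin-1-yl group ended at the limit. Compound 3 is therefore expected to stay at the same footing, with a number no higher from compound 3 to compound 4 (the limit leaves the size open) not readable as a step beyond the scatter. Compound 4 is estimated at 200000 nM, within 60000 nM to 400000 nM, most likely reported again only as a limit.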

Compound 4, half-maximal inhibitory concentration: > 200000 nM
Compound 4: a limit, no number; the forecaster's own chance of this, stated with the estimate: 70%; the middle value sits exactly at the limit.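

Dibutylamino on this aromatic carbon, between two ring nitrogen atoms, gives an at least 3.7-fold higher number from compound 1 to compound 4 (0.57 log units; beyond the scatter), so a third replacement of the 4-methylpiperazin-1-yl group, this one with no ring and a single nitrogen, goes the same way as the first two. In this assay compound 4 also gives only a limit, > 200000 nM. The steps among compound 2, compound 3 and compound 4 cannot be read, so no order can be given among these three groups, and compound 1 alone has a measured number: the limit of > 200000 nM in this assay, at which 3 of the 4 values shown sit.

Going by these compounds, whether the 4-methylpiperazin-1-yl group is the only one here to give a number stays open, since a morpholin-4-yl group or an unsubstituted piperazin-1-yl group could either reach the limit or not. On these data alone, how far compound 2, compound 3 and compound 4 actually lie beyond that limit also stays open.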